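The source may report more compounds than this note shows. Statements on the series, on what has been measured and on what is new or still open speak of the compounds shown alone.

Measured so far: compound 1 `CCCCCCCCC(O)[C@H](CCC)NC(=O)[C@@H](NC(=O)[C@@H](NC(=O)OC(C)(C)C)C(C)C)C(C)C` 1070 nM; compound 2 `CCCCCCCCC(O)[C@H](CC(C)C)NC(=O)[C@@H](NC(=O)[C@@H](NC(=O)OC(C)(C)C)C(C)C)C(C)C` 790 nM; compound 3 `CCCCC(O)[C@@H](NC(=O)[C@@H](NC(=O)[C@@H](NC(=O)OC(C)(C)C)C(C)C)C(C)C)[C@@H](C)CC` 33000 nM.

Compound 3 stands highest of the three numbers in an assay on isolated protein for inhibition of Pepsin A (Homo sapiens) (a higher number here means a weaker inhibitor, a lower number a stronger inhibitor), well beyond the scatter from both others. Compound 4 `CCCCCCCCC(O)[C@@H](NC(=O)[C@@H](NC(=O)[C@@H](NC(=O)OC(C)(C)C)C(C)C)C(C)C)[C@@H](C)CC` takes the step (butyl in place of hydrogen on a saturated chain carbon, five bonds along the chain from an oxygen on a saturated carbon). Among the measured compounds shown here, the only measured step, a 1.4-fold lower number from compound 1 to compound 2 (0.13 log units; within the scatter), concerns a different side chain and stays within the scatter, so it says nothing about the butyl. Compounds 1 and 2 carry the long chain that compound 4 gains, and their values lie far below that of compound 3, though each also differs from compound 3 elsewhere. A large fall is therefore expected, a 22-fold lower number from compound 3 to compound 4 (1.34 log units; beyond the scatter), bringing compound 4 near compounds 1 and 2. The expected value for compound 4 is 1500 nM, within 500 nM to 5000 nM.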

Compound 4, half-maximal inhibitory concentration: 15000 nM
For compound 4 the middle estimate is 10-fold (1.00 log units) below the measured one, and the stated range ends below it.
By their numbers in this assay, from the lowest: compounds 2 and 1 (each within the scatter of the next); then compound 4; then compound 3.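

In this assay, the butyl on this carbon brings only a modest gain (a 2.2-fold lower number from compound 3 to compound 4 (0.34 log units; beyond the scatter)), so the long chain alone does not bring a compound near compounds 1 and 2. The other side chain matters more: sec-butyl in place of isobutyl gives a 19-fold higher number from compound 2 to compound 4 (1.28 log units; beyond the scatter), and methyl in place of hydrogen on the carbon bound to two saturated chain carbons gives a 14-fold higher number from compound 1 to compound 4 (1.15 log units; beyond the scatter), whereas the methyl of the step of a 1.4-fold lower number from compound 1 to compound 2 (0.13 log units; within the scatter) changed nothing measurable. No measurement here explains this difference. From the compounds shown here alone, whether a longer chain or an amine at the end of the hexyl-length chain would shift the number remains open.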